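Replacing a Methylphenyl Group and the Expected Result

A few compounds are considered here, and "the series" means these few. Any claim that something is new, unique, unknown or untested is made for them only; others in the source may bear on it.

In a functional assay on A549 cells (Homo sapiens) for inhibition, read by CCK-8 assay (on this read-out higher numbers stand for weaker inhibition and lower numbers for stronger inhibition), three compounds have been measured so far:
compound 1 `Oc1ccccc1/C=N/c1nnc(SCc2nnc(-c3ccc(F)cc3)o2)s1` gives 20100 nM;
compound 2 `Oc1ccccc1/C=N/c1nnc(SCc2nnc(-c3ccccc3Cl)o2)s1` gives 18100 nM;
compound 3 `Cc1ccccc1-c1nnc(CSc2nnc(/N=C/c3ccccc3O)s2)o1` gives 7850 nM.

Compound 3 shows the lowest number of the three. The steps of a 2.6-fold lower number from compound 1 to compound 3 (0.41 log units; beyond the scatter) and a 2.3-fold lower number from compound 2 to compound 3 (0.36 log units; beyond the scatter) are both modest yet beyond the scatter, while a 1.1-fold lower number from compound 1 to compound 2 (0.05 log units; within the scatter) lies within it. Compound 4 `COc1ccc(-c2nnc(CSc3nnc(/N=C/c4ccccc4O)s3)o2)cc1` differs from compound 3 by 4-methoxyphenyl in place of 2-methylphenyl on an aromatic carbon. Within the data shown here, no measured step introduces a methoxy group, so none bears directly on this change; all three steps seen so far are small, and a small step is the most plausible outcome here too. Compound 4 is therefore expected to give 11000 nM, with a likely range from 4500 nM to 27000 nM, which would mean an estimated step of a 1.4-fold higher number from compound 3 to compound 4 (0.15 log units; within the scatter).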

Compound 4, half-maximal inhibitory concentration: 20300 nM
Compound 4: the middle estimate sits 1.8-fold (0.27 log units) below what was measured; the measured number falls inside the stated range.
By their numbers in this assay, from the lowest: compound 3; then compounds 2, 1 and 4 (each within the scatter of the next).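

Swapping 2-methylphenyl for 4-methoxyphenyl gives a higher number (a 2.6-fold higher number from compound 3 to compound 4 (0.41 log units; beyond the scatter)), so this position does respond to a change of its aryl group. Compound 4 stays within the scatter of the other two compounds (a 1.1-fold higher number from compound 2 to compound 4 (0.05 log units; within the scatter); a 1.0-fold higher number from compound 1 to compound 4 (0.00 log units; within the scatter)), which leaves compound 3, with its 2-methylphenyl, alone at the low end. No measured evidence here explains this difference.

Still open, on these data alone, is whether the lower number follows the methyl group or its place on the phenyl ring, which a 4-methylphenyl or 2-methoxyphenyl compound could separate. How an amine on that phenyl ring would behave is also unknown.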